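Compound 3: Amino in Place of Trifluoromethyl

This account rests on a few compounds, and the source may have more. Where it says the series, first, only, none or still open, it means among the compounds named here.

Compound 1 `Cc1cccc(Cn2c(=O)[nH]c3c(N)nc(C(F)(F)F)cc32)n1` reads 2.3 on partition
Compound 2 `Nc1nc(C(F)(F)F)cc2c1[nH]c(=O)n2Cc1ccc(C(F)(F)F)nc1` reads "not determined" (no result reported) on partition

In a physicochemical assay for lipophilicity, measured as octanol-water partition, at pH 7.4 (on this read-out lower numbers stand for lower lipophilicity and higher numbers for higher lipophilicity), compound 2 gives no single number (its entry reads "not determined" (no result reported)) and so has no standing on the scale, while compound 1 at 2.3 provides the only measured figure. Compound 3 `Nc1ccc(Cn2c(=O)[nH]c3c(N)nc(C(F)(F)F)cc32)cn1` has not yet been measured. The change amino in place of trifluoromethyl on an aromatic carbon is amino in place of trifluoromethyl on an aromatic carbon. Within the data shown here, a large step toward lower numbers in this assay is expected, although no measured pair shows its size. The estimate for compound 3 is 1.6 with an expected range (1.1 to 2.1).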

Compound 3, distribution coefficient: 1.5
Compound 3: middle estimate off by 0.10 log units, on the high side; measured number inside the range.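

In this assay the series now has its first readable step, a number 0.80 log units lower from compound 1 to compound 3 (beyond the scatter), with 6-aminopyridin-3-yl in place of 6-methylpyridin-2-yl on the saturated chain carbon bound to an aromatic nitrogen. The step from compound 2 to compound 3 cannot be read, so amino in place of trifluoromethyl still has no measured size of its own. Nothing measured here accounts for the step from compound 1.

The compounds shown leave open where a hydroxyl, a dimethylamine or a carboxylic acid in place of the amino would fall on this scale.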